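Swapping Chloro for Iodo on a Shared Amide Core

A few compounds are considered here, and "the series" means these few. Any claim that something is new, unique, unknown or untested is made for them only; others in the source may bear on it.

Compound 3 `O=C(Nc1ccc(Oc2cc(C(F)(F)F)cc(C(F)(F)F)c2)cc1O)c1c(F)cccc1Cl` gives 4020 nM in an assay on HEK293 cells for inhibition of Toll-like receptor 8 (Homo sapiens), with a stated time of 16 h; a lower number here means a stronger inhibitor, a higher number a weaker inhibitor. Its two companions on the shared core are compound 1 `O=C(Nc1ccc(Oc2cc(C(F)(F)F)cc(C(F)(F)F)c2)cc1)c1c(F)cccc1Br`, which gives 6000 nM, and compound 2 `O=C(Nc1ccc(Oc2cc(C(F)(F)F)cc(C(F)(F)F)c2)cc1)c1sccc1Cl`, which gives 3200 nM; all three numbers lie within the scatter of one another, so none stands apart. Compound 4 `O=C(Nc1ccc(Oc2cc(C(F)(F)F)cc(C(F)(F)F)c2)cc1O)c1c(F)cccc1I` differs from compound 3 by iodo in place of chloro on an aromatic carbon. Going by the values given here, the only measured step, a 1.9-fold lower number from compound 1 to compound 2 (0.27 log units; within the scatter), replaces a whole ring rather than a single halogen, so it says little about this change, and no measured pair swaps one halogen for another. With nothing pointing either way, the step from compound 3 to compound 4 is expected to stay within the scatter, a 1.1-fold lower number from compound 3 to compound 4 (0.06 log units; within the scatter). Compound 4 is therefore estimated at 3500 nM, with a range from 1400 nM to 9000 nM.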

Compound 4, half-maximal inhibitory concentration: 2630 nM
Estimate against measurement, compound 4: 1.3-fold (0.12 log units) above, within the range that was stated.
By their numbers in this assay, from the lowest: compounds 4, 2, 3 and 1 (each within the scatter of the next, the first and the last beyond it).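

Going by these compounds alone, this is the first measured swap of one halogen for another at a single position: iodo in place of chloro, ortho to a large group and meta to a fluoro group, gives a 1.5-fold lower number from compound 3 to compound 4 (0.18 log units; within the scatter) in this assay. The step stays within the scatter, so in this small set the position accepts either halogen without a clear change in the number. Nothing at hand speaks to the cause of this result.

On these data alone, what an amine or a methoxy group would do at this position stays open. So does whether iodo in place of chloro gives a similar step on the core of compound 1.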